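Methyl to Hydrogen on an Aromatic Nitrogen in Caco-2 Cells

The source may report more compounds than this note shows. Statements on the series, on what has been measured and on what is new or still open speak of the compounds shown alone.

Compound 1 `Cn1c(/C=C/C(=O)c2ccccc2O)cc(Br)c1Br` was tested in a functional assay on Caco-2 cells (Homo sapiens) for cytotoxicity, read by MTT assay, with stated times of 6 h and 48 h (on this read-out lower numbers stand for stronger inhibition and higher numbers for weaker inhibition), where compound 1 gives 3160 nM. Compound 3 `O=C(/C=C/c1cc(Br)c(Br)[nH]1)c1ccccc1O` differs from compound 1 by a single change: hydrogen in place of methyl on an aromatic nitrogen. In this assay compound 3 reaches only a limit of the assay, >= 100000 nM. The step is therefore an at least 31-fold higher number from compound 1 to compound 3 (1.50 log units; beyond the scatter), and its reading rests on (the limit of >= 100000 nM in this assay, at which 2 of the 3 values shown sit). Compound 2 `COc1ccc(C(=O)/C=C/c2cc(Br)c(Br)n2C)c(OC)c1` carries another core; the difference between the two cores is not broken down here. In this assay compound 2 likewise reaches only a limit of the assay, >= 100000 nM. Compound 4 `COc1ccc(C(=O)/C=C/c2cc(Br)c(Br)[nH]2)c(OC)c1` has not yet been measured. Among the measured compounds shown here, it differs from compound 2 by hydrogen in place of methyl on an aromatic nitrogen, the same change, at the same place, as the one between compound 1 and compound 3. Because that change gave an at least 31-fold higher number from compound 1 to compound 3 (1.50 log units; beyond the scatter), compound 4 is expected to remain at the limit of this assay, with an expected step that the limit leaves unreadable from compound 2 to compound 4. The estimate for compound 4 in this assay is 200000 nM, expected to lie between 100000 nM and 600000 nM.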

Compound 4, half-maximal inhibitory concentration: >= 100000 nM
Compound 4: no number, only a limit; the forecaster's own chance of this, stated with the estimate: 90%; the middle value does not contradict the limit.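

Compound 4, like compound 2, reaches only a limit in this assay, so no step can be read from compound 2 to compound 4, and the reading rests on this: the limit of >= 100000 nM in this assay, at which 3 of the 4 values shown sit.

The compounds shown leave open how large the change from methyl to hydrogen on the aromatic nitrogen is on the core of compound 2.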